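A few compounds are considered here, and "the series" means these few. Any claim that something is new, unique, unknown or untested is made for them only; others in the source may bear on it.

Three compounds share one core, carrying an amino-substituted chain on one side and a saturated bicyclic amine on the other. Compound 1 `OCC(O)CNc1cc(N2CCc3ccccc3C2)nc2ccccc12` gives in an ADME assay on HEp-2 cells (Homo sapiens) for cytotoxicity, read by CCK-8 assay, with a stated time of 5 days (on this read-out lower numbers stand for higher toxicity in this test and higher numbers for lower toxicity in this test), a value of 66000 nM, while compound 2 `CC(O)CNc1cc(N2CCc3ccccc3C2)nc2ccccc12` gives in this assay 89000 nM. Among the compounds with values here, the only single-point step among the measured compounds, a 1.3-fold higher number from compound 1 to compound 2 (0.13 log units; within the scatter), is a chain change with no effect beyond the scatter. Compound 3 `Cc1ccc2nc(N3CCCc4ccc(F)cc4C3)cc(NCC(C)N)c2c1` gives in this assay 86000 nM, a number that sits between those of compound 1 and compound 2, with both gaps within the scatter, so the three measured compounds are indistinguishable on this read-out.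

Compound 4 `CC(=O)NCCNc1cc(N2CCCc3ccc(F)cc3C2)nc2ccc(C)cc12` differs from compound 3 in one place: acetamidomethyl in place of 1-aminoethyl on a saturated chain carbon bound to a nitrogen on an aromatic ring. Within the data shown here, no measured step covers exactly this exchange. Among the measured compounds shown here, the nearest precedent is the chain edit from compound 1 to compound 2, which left the number unchanged within the scatter, and the whole set spans a narrow band. On that basis the expected step of no change at the digits printed from compound 3 to compound 4 (within the scatter) is none beyond the scatter. Compound 4 is therefore estimated at 86000 nM in this assay, with a likely range from 40000 nM to 180000 nM.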

Compound 4, half-maximal cytotoxic concentration: 66000 nM
Beside the measured number, compound 4's estimate is 1.3-fold (0.11 log units) above it; measured number inside the range.
By their numbers in this assay, from the lowest: compounds 1, 4, 3 and 2 (each within the scatter of the next).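

In this assay, the exchange of 1-aminoethyl for acetamidomethyl gives a 1.3-fold lower number from compound 3 to compound 4 (0.11 log units; within the scatter), so this read-out does not separate the two compounds. The earlier step had tested only the loss of a hydroxy group on the chain of compound 1, whereas this one shows that a larger edit on a saturated chain carbon bound to a nitrogen on an aromatic ring, going from 3 heavy atoms to 5 and bringing in an amide carbonyl, also stays within the scatter, here on the core of compound 3. The evidence at hand offers no measurement that bears on this result and gives no account of it.

The compounds shown leave open whether a carboxylic acid, a longer chain or a morpholine ring at this place would move the number beyond the scatter in this assay. They also leave open whether the acetamidomethyl exchange would read the same on the core of compound 1, and whether a change to the saturated bicyclic amine would separate compounds where these chain edits do not.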